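Working notes: estimate for compound 4 in the antiproliferative series

The compounds below may be only part of what the source reports. "The series", "measured", "known", "first", "only" and "open" are said of these compounds alone.

Measured so far:
compound 1 `CCN1CCN(c2cc(C)c3cc(NC(=O)c4ccccc4C)ccc3n2)CC1` — 10900 nM
compound 2 `Cc1cc(NCCN2CCN(C)CC2)nc2ccc(NC(=O)c3ccc(Cl)c(Cl)c3)cc12` — 1700 nM
compound 3 `Cc1cc(N2CCCCC2)nc2ccc(NC(=O)c3ccc(Cl)c(Cl)c3)cc12` — 31100 nM

All values come from a functional assay on MCF7 cells (Homo sapiens) for antiproliferative activity, read by MTT assay, with a stated time of 72 h; on this read-out lower numbers stand for stronger inhibition and higher numbers for weaker inhibition. Compound 1 stands second highest of the three numbers: compound 3 gives 31100 nM, a higher number beyond the scatter, while compound 2 gives 1700 nM, a lower number beyond the scatter.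

Compound 4 `CCN1CCN(c2cc(C)c3cc(NC(=O)c4ccccc4Cl)ccc3n2)CC1` differs from compound 1 by chloro in place of methyl on an aromatic carbon. Among the compounds with values here, the only measured step, an 18-fold higher number from compound 2 to compound 3 (1.26 log units; beyond the scatter), alters the amine-bearing end of the shared core and leaves the (2-methylphenyl)carbonyl part untouched; no measured pair varies that part alone, so nothing bears directly on the present change. For compound 4 a step within the scatter is therefore expected, a 1.2-fold lower number from compound 1 to compound 4 (0.08 log units; within the scatter). Compound 4 is estimated at 9000 nM, with a range from 3500 nM to 25000 nM.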

Compound 4, half-maximal inhibitory concentration: > 50000 nM
Compound 4 was reported as a limit; the forecaster's own chance of this, stated with the estimate: 5%; middle value at least 5.5-fold (0.74 log units) from the limit.
By their numbers in this assay, from the lowest: compound 2; then compound 1; then compound 3. At a limit, above all of these: compound 4.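

Chloro in place of methyl, ortho to a large group, gives an at least 4.5-fold higher number from compound 1 to compound 4 (0.66 log units; beyond the scatter); this place on the (2-methylphenyl)carbonyl part, which the earlier step left untouched, therefore matters in this assay. Compound 4 stands only as a limit, so the full size of this step stays unknown: the limit of > 50000 nM in this assay, at which 1 of the 4 values shown sits.

Open, from the compounds shown here alone, is whether a fluoro, a methoxy or an amine at this place would keep the number of compound 1 or raise it as chloro does. Also open, going by these compounds, is whether the same exchange gives a similar step with the (2-(4-methylpiperazin-1-yl)ethyl)amino group on the shared core.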